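A Hexyloxy Chain Replaces Methylsulfanyl on the Shared Core

The source may hold more compounds than are shown below. What is called first, only, known or untested is meant among the compounds shown, and "the series" means these compounds.

Of the compounds shown here, three built on one shared core have been measured in an ADME assay on CCRF-HSB-2 cells (Homo sapiens) for cytotoxicity, with a stated time of 7 days; on this read-out higher numbers stand for lower toxicity in this test and lower numbers for higher toxicity in this test. Compound 1 `Nc1nc(NCc2ccccc2)c2ncn(/C=C3/CC3(CO)CO)c2n1` carries a benzylamino group; in this assay compound 1 gives > 20000 nM, which is a limit of the assay and not a number. Compound 2 `CCCCCCSc1nc(N)nc2c1ncn2/C=C1/CC1(CO)CO` carries a hexylsulfanyl group, and in this assay compound 2 gives 60000 nM. Compound 3 `CSc1nc(N)nc2c1ncn2/C=C1/CC1(CO)CO` carries a methylsulfanyl group; in this assay compound 3 gives > 100000 nM, again a limit rather than a number. Compound 3 thus sits at the limit of > 100000 nM in this assay, at which 1 of the 3 values shown sits. Going by the values given here, only the step of an at least 1.6-fold higher number from compound 2 to compound 3 (0.22 log units; that floor lies within the scatter) is readable, while a step that the limit leaves unreadable from compound 1 to compound 2 and a step that the two limits leave unreadable from compound 1 to compound 3 cannot be sized.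

Compound 4 `CCCCCCOc1nc(N)nc2c1ncn2/C=C1/CC1(CO)CO` has not yet been measured. It differs from compound 3 by hexyloxy in place of methylsulfanyl on an aromatic carbon. Among the compounds with values here, the one measured step bearing on this change is an at least 1.6-fold higher number from compound 2 to compound 3 (0.22 log units; that floor lies within the scatter), in which a long chain gave way to hydrogen and the number rose by an amount whose floor lies within the scatter. The hexyloxy chain entering in compound 4 runs the other way, so a modest fall in the number is expected, roughly an at least 1.4-fold lower number from compound 3 to compound 4 (0.15 log units; that floor lies within the scatter), though a limit is also quite possible. Compound 4 is therefore estimated at 70000 nM, within 30000 nM to 150000 nM.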

Compound 4, half-maximal cytotoxic concentration: > 20000 nM
Compound 4: a limit, no number; the forecaster's own chance of this, stated with the estimate: 40%; the middle value lies beyond the limit too.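

Compound 4 gives a limit and not a number in this assay, and none of the steps from compound 1, compound 2 or compound 3 to compound 4 can be read. The compounds shown leave open whether hexyloxy in place of hexylsulfanyl or methylsulfanyl on the shared core changes the number at all, and by how much.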